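Solubility across three aryl substituents on the shared core

The source may hold more compounds than are shown below. What is called first, only, known or untested is meant among the compounds shown, and "the series" means these compounds.

Measured so far in a physicochemical assay for solubility, with a stated time of 18 h, at pH 7.4; on this read-out higher numbers stand for higher solubility and lower numbers for lower solubility:
compound 1 `COc1ccc(F)cc1CNCCCNc1ccnc2cc(C3CCCCC3)ccc12` gives 4200 nM;
compound 2 `CCC(CC)c1ccc2c(NCCCNCc3cccc(OC)c3O)ccnc2c1` gives 4200 nM;
compound 3 `COc1cccc(CNCCCNc2ccnc3cc(CC(C)C)ccc23)c1O` gives 4200 nM.

Compound 3 stands level with compounds 1 and 2 at the digits shown. Among the compounds with values here, the one measured step that differs in a single place, no change at the digits printed from compound 2 to compound 3 (within the scatter), is the replacement of pentan-3-yl by isobutyl on an aromatic carbon, and it leaves this assay unchanged within the scatter. Compound 1 and compound 3 are not a listed single-place step, but their two values show no difference at the digits printed.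

Compound 4 `COc1cccc(CNCCCNc2ccnc3cc(C4CCCCC4)ccc23)c1O` is not yet measured. It differs from compound 3 as follows: cyclohexyl in place of isobutyl on an aromatic carbon. The change bears on the same aromatic carbon as the step from compound 2 to compound 3, and the group that enters in compound 4 is the same cyclohexyl that compound 1 carries. Within the data shown here, compound 1 gives 4200 nM and compound 3 gives 4200 nM, so nothing among the measured compounds points to a shift beyond the scatter.

The step from compound 3 to compound 4 is therefore expected to be no change at the digits printed from compound 3 to compound 4 (within the scatter), essentially none. Compound 4 is estimated at 4200 nM, with a range from 2100 nM to 8400 nM.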

Compound 4, solubility: 4200 nM
Beside the measured number, compound 4's estimate shows no gap at the digits printed; the measured number falls inside the stated range.
By their numbers in this assay, from the lowest: compounds 1, 2, 3 and 4 (each within the scatter of the next).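

In this assay the aromatic carbon now carries a ring as well as open branched groups, with the 2-hydroxy-3-methoxyphenyl side held fixed: cyclohexyl in place of isobutyl reads as no change at the digits printed from compound 3 to compound 4 (within the scatter) and cyclohexyl in place of pentan-3-yl reads as no change at the digits printed from compound 2 to compound 4 (within the scatter) in the same assay. With cyclohexyl held fixed, a change away from that aromatic carbon can now be read as well, since 2-hydroxy-3-methoxyphenyl in place of 5-fluoro-2-methoxyphenyl on a saturated chain carbon bound to an amine nitrogen gives no change at the digits printed from compound 1 to compound 4 (within the scatter) on this read-out. Both places on the shared core have therefore tolerated the changes shown without any departure from the scatter, though this holds only for these four compounds and for carbon-only groups at the aromatic carbon.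

As far as these compounds go, whether an amine, a carboxylic acid or a longer chain at this aromatic carbon would stay level with these four in this assay remains open. No measurement shown here offers an account of why the four values stand level.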